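Compound 4: dichlorophenyl in place of aminophenyl

A few compounds are considered here, and "the series" means these few. Any claim that something is new, unique, unknown or untested is made for them only; others in the source may bear on it.

Of the compounds shown here, three have been read so far in a functional assay on Jurkat cells (Homo sapiens) for antiproliferative activity, read by MTT assay, with a stated time of 72 h (a higher number here means a weaker inhibitor, a lower number a stronger inhibitor), and none gives a number. Compound 1 (`COc1cc(-c2ncnn2-c2ccc([N+](=O)[O-])cc2)cc(OC)c1OC`) reads > 10000 nM as a limit of the assay. Compound 2 (`COc1cc(-c2ncnn2-c2ccc(N)cc2)cc(OC)c1OC`) reads > 10000 nM as a limit too, so its standing in the series is a limit and not a number. Compound 3 (`COc1cc(-n2ncnc2-c2ccccc2)cc(OC)c1OC`) likewise reads > 10000 nM as a limit. The series therefore offers only the limit of > 10000 nM in this assay, at which 3 of the 3 values shown sit, as a reference point.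

Compound 4 (`COc1cc(-c2ncnn2-c2ccc(Cl)c(Cl)c2)cc(OC)c1OC`) carries 3,4-dichlorophenyl in place of 4-aminophenyl on an aromatic nitrogen and keeps the rest of compound 2 unchanged. Among the compounds with values here, the only measured step is a step that the two limits leave unreadable from compound 1 to compound 2 and gives no size to carry over to this change. Within the data shown here, no measured step covers a chlorinated ring.

In this assay no clear gain is therefore expected, and compound 4 will most likely be reported as a limit again. The expected step is a number no higher from compound 2 to compound 4 (the limit leaves the size open) and it should be read as no firm change in either direction. For compound 4 the estimate is 10000 nM with an expected range from 2500 nM to 30000 nM in this assay.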

Compound 4, half-maximal inhibitory concentration: > 10000 nM
Compound 4 ended at the assay's limit; the forecaster's own chance of this, stated with the estimate: 70%; the middle value lies on the limit itself.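

Compound 4 gives > 10000 nM in this assay as a limit of the assay, so no step can be read between compound 2 and compound 4. The series holds a single reference point: the limit of > 10000 nM in this assay, at which 4 of the 4 values shown sit.

The compounds shown leave open whether any group on the aromatic nitrogen brings a value off this limit in this assay.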